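A bare phenyl replaces 2,6-dimethoxyphenyl in compound 3

This account rests on a few compounds, and the source may have more. Where it says the series, first, only, none or still open, it means among the compounds named here.

Going by the values given here, only two compounds have numbers so far. Among the compounds with values here, in a functional assay on MDA-MB-231 cells (Homo sapiens) for antiproliferative activity, read by CCK-8 assay, with a stated time of 72 h (on this read-out lower numbers stand for stronger inhibition and higher numbers for weaker inhibition), compound 2 (`COc1cccc(OC)c1C(=O)Nc1ccc(C(=O)/C=C/c2nc(C)c(C)nc2C)cc1`) reads 3850 nM and compound 1 (`COc1cc(C(=O)Nc2ccc(C(=O)/C=C/c3nc(C)c(C)nc3C)cc2)cc(OC)c1OC`) reads 4740 nM and the two values lie within the scatter of each other, so compound 2 stands level with the only other measured compound.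

Compound 3 (`Cc1nc(C)c(/C=C/C(=O)c2ccc(NC(=O)c3ccccc3)cc2)nc1C`) has not yet been measured. It differs from compound 2 by phenyl in place of 2,6-dimethoxyphenyl on a carbonyl carbon, and the full count of that change is phenyl in place of 2,6-dimethoxyphenyl on a carbonyl carbon with the rest of the structure untouched.

Within the data shown here, no measured pair shows what this change does, so the data offer no direct guide. The only hint is the narrow spread, with compound 1 at 4740 nM and compound 2 at 3850 nM in the same range, and no large shift is expected. The expected outcome in this assay is a small rise in the number, a 1.2-fold higher number from compound 2 to compound 3 (0.07 log units; within the scatter) and nothing beyond the scatter. The estimated value for compound 3 is 4500 nM with an expected range from 1800 nM to 11000 nM in this measurement.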

Compound 3, half-maximal inhibitory concentration: 1840 nM
The estimate for compound 3 lay 2.4-fold (0.39 log units) above the measured number, and the stated range covers the measured number.
By their numbers in this assay, from the lowest: compound 3; then compounds 2 and 1 (each within the scatter of the next).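

Phenyl in place of 2,6-dimethoxyphenyl on a carbonyl carbon whose other neighbour is the amide-type nitrogen gives, in this assay, a 2.1-fold lower number from compound 2 to compound 3 (0.32 log units; beyond the scatter), a modest change but the first one in this series that can be read at all. It shows that this position responds to what the aromatic ring carries, and that the antiproliferative activity seen here does not depend on the two methoxy groups, since the number falls when they are gone. Nothing at hand accounts for the direction of this step, and the data give no reason for it.

The compounds shown leave open whether it is the loss of both methoxy groups that matters, or whether a ring with a single methoxy group would read like the bare phenyl. They also leave open whether a different group on this ring, such as a fluorine atom, an amine or a carboxylic acid, would lower the number further or raise it again, so this one step marks no trend.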